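The compounds below may be only part of what the source reports. "The series", "measured", "known", "first", "only" and "open" are said of these compounds alone.

Measured so far in a functional assay on LoVo cells (Homo sapiens) for inhibition, read by colorimetric assay and MTT assay, with a stated time of 72 h; a lower number here means a stronger inhibitor, a higher number a weaker inhibitor:
compound 1 `Cn1c2cnc1OCCCCCCCCOc1ccc(F)cc1-2` gives 43000 nM
compound 2 `C=CCCCCOc1ccc(OC)cc1-c1cnc(OCCC=C)n1C` gives 33000 nM
compound 3 `C=CCCCCOc1cc2ccccc2cc1-c1cnc(OCCC=C)n1C` gives 25000 nM

Compound 3 at 25000 nM has the lowest number of the three, but it lies within the scatter of both other compounds, so the numbers do not separate it from them.

The next compound is compound 4 `C=CCCCCOc1cc2ccccc2cc1-c1cnc(OCCCCC=C)n1C`, not yet measured. It keeps compound 3 except for one chain, with but-3-en-1-yl in place of vinyl on a saturated chain carbon, two bonds along the chain from an oxygen on an aromatic ring. The same difference reads as (but-3-en-1-yl)oxy to (hex-5-en-1-yl)oxy. Counted, this is but-3-en-1-yl in place of vinyl on a saturated chain carbon, two bonds along the chain from an oxygen on an aromatic ring and nothing else changes.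

For the measured compounds named here, no measured pair differs in one place only, so no measured step can be carried over to this change. The expectation in this assay is therefore no step beyond the scatter, with only a slight lean toward a lower number. The support is thin: compound 1 at 43000 nM and compound 2 at 33000 nM both stay within the scatter of compound 3.

The expected change is a 1.1-fold lower number from compound 3 to compound 4 (0.06 log units; within the scatter) and remains an estimate.

For compound 4 the estimated value is 22000 nM with an expected range from 10000 nM to 45000 nM in this estimate.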

Compound 4, half-maximal inhibitory concentration: 25000 nM
Compound 4: middle estimate off by 1.1-fold (0.06 log units), on the low side, and the stated range covers the measured number.
By their numbers in this assay, from the lowest: compounds 3, 4, 2 and 1 (each within the scatter of the next).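

In this assay the series now has a single-place step to read: but-3-en-1-yl in place of vinyl on a saturated chain carbon, two bonds along the chain from an oxygen on an aromatic ring, gives no change at the digits printed from compound 3 to compound 4 (within the scatter). The same difference, read as (but-3-en-1-yl)oxy to (hex-5-en-1-yl)oxy, therefore leaves the number at this position unmoved, with one double bond outside aromatic rings on each side and no ring, hydrogen-bond donor, hydrogen-bond acceptor or net charge entering. No measured evidence accompanies this step, so the flat result stands without an explanation.

From the compounds shown here alone, whether a chain longer than hex-5-en-1-yl, or a chain ending in an amine, a carboxylic acid or a phenyl ring, would keep the number in place at this position remains open. Also open, going by these compounds, is whether any single-place change on the shared core moves the number beyond the scatter at all.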